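A few compounds are considered here, and "the series" means these few. Any claim that something is new, unique, unknown or untested is made for them only; others in the source may bear on it.

Compound 1 `CC(C)(C)OC(=O)N(Cc1ccco1)C(=O)c1ccc(CN2Cc3ccccc3C2=O)cc1` gives 95200 nM in an ADME assay on RAW264.7 cells (Mus musculus) for cytotoxicity, read by WST assay; a higher number here means that more compound is tolerated, a lower number that less compound is tolerated. Compound 2 `O=C(NCc1ccco1)c1ccc(CN2Cc3ccccc3C2=O)cc1` gives only a limit of the assay, > 100000 nM, in this assay. The change from compound 1 to compound 2 is hydrogen in place of tert-butoxycarbonyl on an amide-type nitrogen, and it made an at least 1.0-fold higher number from compound 1 to compound 2 (0.02 log units; that floor lies within the scatter); that floor sits at the limit of > 100000 nM in this assay, at which 1 of the 3 values shown sits. Compound 3 `CC(C)(C)OC(=O)N(Cc1ccco1)C(=O)c1ccc(Cn2c(=O)c3ccccc3[s+]2[O-])cc1` gives 87300 nM in this assay, and its core differs from that of compound 1 by a group of 11 heavy atoms (7 carbon, 1 nitrogen, 2 oxygen, 1 sulfur; one five-membered aromatic ring with 2 hetero atoms, one six-membered aromatic ring of carbon only) in place of a group of 10 heavy atoms (8 carbon, 1 nitrogen, 1 oxygen; one five-membered non-aromatic ring with 1 hetero atom, one six-membered aromatic ring of carbon only), on a saturated chain carbon bound to an aromatic carbon, a step of a 1.1-fold lower number from compound 1 to compound 3 (0.04 log units; within the scatter). Compound 4 `O=C(NCc1ccco1)c1ccc(Cn2c(=O)c3ccccc3[s+]2[O-])cc1` is not yet measured in this assay. It differs from compound 3 by hydrogen in place of tert-butoxycarbonyl on an amide-type nitrogen, the same kind of change as from compound 1 to compound 2, with the place described in the same words. Beside that earlier step, compound 4 is expected to show a 1.2-fold higher number from compound 3 to compound 4 (0.08 log units; within the scatter) from compound 3, resting on an at least 1.0-fold higher number from compound 1 to compound 2 (0.02 log units; that floor lies within the scatter) in this assay. Compound 4 is estimated at 105000 nM, between 60000 nM and 200000 nM.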

Compound 4, concentration lethal to 50% of the cells: > 100000 nM
Compound 4 ended at the assay's limit; the forecaster's own chance of this, stated with the estimate: 60%; the middle value does not contradict the limit.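

Hydrogen in place of tert-butoxycarbonyl on the amide-type nitrogen gives an at least 1.1-fold higher number from compound 3 to compound 4 (0.05 log units; that floor lies within the scatter) in this assay. Carried from the core of compound 1 to the core of compound 3, the change ends at a limit of the assay on both, so the two steps can be set side by side only as floors: the same change on two cores in this assay, an at least 1.0-fold higher number (0.02 log units; that floor lies within the scatter) from compound 1 to compound 2 and an at least 1.1-fold higher number (0.05 log units; that floor lies within the scatter) from compound 3 to compound 4; the limit leaves it open whether they differ Neither the size of the change on either core nor any real gain in tolerated concentration can be read from these results, and some of the values shown are limits: the limit of > 100000 nM in this assay, at which 2 of the 4 values shown sit.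

On these data alone, the actual numbers of compound 2 and compound 4 remain open. Also open, as far as these compounds go, is how a smaller acetyl group or a methyl group on that nitrogen would read in this assay.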